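A few compounds are considered here, and "the series" means these few. Any claim that something is new, unique, unknown or untested is made for them only; others in the source may bear on it.

Measured in a physicochemical assay for solubility, read by LC-MS, in phosphate buffer, with a stated time of 24 h, at pH 7.4; a higher number here means a more soluble compound, a lower number a less soluble compound:
- compound 1 `CC1(C)CC(=O)N(c2cnc(NCc3c(F)ccc4c3CCO4)n3cnnc23)C1`: 57000 nM
- compound 2 `C[C@H]1CC(=O)N(c2cnc(NCc3c(F)ccc4c3CCO4)n3cnnc23)C1`: 200000 nM

Compound 2 stands the higher of the two, and its value is the starting point here. Compound 3 `Fc1ccc2c(c1CNc1ncc(Nc3ccccc3)c3nncn13)CCO2` carries anilino in place of 4-methyl-2-oxopyrrolidin-1-yl on an aromatic carbon. Going by the values given here, only one measured step bears on this, and it is modest: a 3.5-fold higher number from compound 1 to compound 2 (0.55 log units; beyond the scatter). That step swaps one 2-oxopyrrolidin-1-yl group for another, whereas compound 3 loses that group entirely. Among the compounds with values here, no measured compound carries anilino, so the direction rests on judgement, and a larger step towards a lower number is expected. The expected change is an 8.0-fold lower number from compound 2 to compound 3 (0.90 log units; beyond the scatter). For compound 3, the estimated value is 25000 nM, with an expected range of 5000 nM to 100000 nM.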

Compound 3, solubility: 3000 nM
Beside the measured number, compound 3's estimate is 8.3-fold (0.92 log units) above it, outside the stated range (below it).
By their numbers in this assay, from the lowest: compound 3; then compound 1; then compound 2.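

In this assay this position tolerates far less change than the two 2-oxopyrrolidin-1-yl groups suggested: anilino gives a 67-fold lower number from compound 2 to compound 3 (1.82 log units; beyond the scatter) and also a 19-fold lower number from compound 1 to compound 3 (1.28 log units; beyond the scatter) when set against the other ring. Both large steps run the same way, so the drop does not depend on which of these two groups leaves. Nothing measured here explains the drop.

The swap brings in an aromatic ring and a hydrogen-bond donor together, and the compounds shown cannot separate the two. As far as these compounds go, how a morpholine ring or a carboxylic acid would behave at this position stays open.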